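This account rests on a few compounds, and the source may have more. Where it says the series, first, only, none or still open, it means among the compounds named here.

For the measured compounds named here, in a functional assay on A549 cells (Homo sapiens) for cytotoxicity (on this read-out lower numbers stand for stronger inhibition and higher numbers for weaker inhibition), compound 2 (`CC[C@H]1CCCN1CN1C(=O)c2cccc3c2c(cc2c4ccccc4sc32)C1=O`) gives 580 nM, the lower of the two numbers so far, while compound 1 (`CCC1CCCN1CN1C(=O)c2cccc3c2c(cc2c4ccccc4sc32)C1=O`) gives 2880 nM. Compound 3 (`CC[C@@H]1CCCN1CN1C(=O)c2cccc3c2c(cc2c4ccccc4sc32)C1=O`) changes only the drawn configuration: the two compounds have the same atoms and bonds and differ only in configuration as drawn: 1 of 1 stereo elements differ; a stereocentre at a saturated ring carbon is drawn S in compound 2 and R in compound 3. Going by the values given here, the one measured step bearing on this is a 5.0-fold lower number from compound 1 to compound 2 (0.70 log units; beyond the scatter), which goes with the fact that one of compounds 1 and 2 is drawn with a defined configuration and the other without, at the place where they differ. On the strength of that step, a move to a higher number, of similar or larger size, is expected in this assay. The expected step is a 6.0-fold higher number from compound 2 to compound 3 (0.78 log units; beyond the scatter). For compound 3 the estimated value is 3500 nM, with an expected range of 1200 nM to 10000 nM.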

Compound 3, half-maximal inhibitory concentration: 6020 nM
Compound 3: the middle estimate sits 1.7-fold (0.24 log units) below what was measured; low and high end bracket the measured number.
By their numbers in this assay, from the lowest: compound 2; then compound 1; then compound 3.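

In this assay, the configuration at the saturated ring carbon alone now carries a large change, with the S form on the low side, a 10-fold higher number from compound 2 to compound 3 (1.02 log units; beyond the scatter): the fact that compounds 2 and 3 differ only in the configuration as drawn

The compound drawn without a configuration at this carbon falls between the two defined forms, and the R form also stands apart from it, a 2.1-fold higher number from compound 1 to compound 3 (0.32 log units; beyond the scatter): the fact that one of compounds 1 and 3 is drawn with a defined configuration and the other without, at the place where they differ

As far as these compounds go, whether the S form keeps the lower number with a propyl chain or a hydroxymethyl group at this stereocentre remains open.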